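This account rests on a few compounds, and the source may have more. Where it says the series, first, only, none or still open, it means among the compounds named here.

Compound 2 `CCC1C(=O)N(C)c2cnc(-n3ccc4cc(C(=O)NC)ccc43)nc2N1c1ccn(C)n1` and compound 1 `CCC1C(=O)N(C)c2cnc(-n3ccc4cc(C(=O)NC(C)C)ccc43)nc2N1c1ccn(C)n1` share one core; in a functional assay on HeLa cells (Homo sapiens) for antiproliferative activity, read by CCK-8 assay, with a stated time of 72 h (on this read-out lower numbers stand for stronger inhibition of growth and higher numbers for weaker inhibition of growth), compound 2 gives 6330 nM and compound 1 gives 4350 nM. The change between them is isopropyl in place of methyl on an amide-type nitrogen, and it made a step of a 1.5-fold lower number from compound 2 to compound 1 (0.16 log units; within the scatter). Compound 3 `CC[C@@H]1C(=O)N(C)c2cnc(-n3ccc4cc(C(=O)NC)ccc43)nc2N1C1CCCC1` carries a different core; the difference between the two cores is not broken down here. In this assay compound 3 gives 768 nM, the lowest of the three numbers. Compound 4 `CC[C@@H]1C(=O)N(C)c2cnc(-n3ccc4cc(C(=O)NC(C)C)ccc43)nc2N1C1CCCC1` is not yet measured. It differs from compound 3 by isopropyl in place of methyl on an amide-type nitrogen, the same change already seen from compound 2 to compound 1. The earlier step of a 1.5-fold lower number from compound 2 to compound 1 (0.16 log units; within the scatter) is the basis for the expectation. An expected step of a 1.4-fold lower number from compound 3 to compound 4 (0.14 log units; within the scatter) follows from the earlier step of a 1.5-fold lower number from compound 2 to compound 1 (0.16 log units; within the scatter). Compound 4 is therefore estimated to give 550 nM in this assay, with an expected range from 250 nM to 1300 nM.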

Compound 4, concentration for 50% growth inhibition: 292 nM
Beside the measured number, compound 4's estimate is 1.9-fold (0.27 log units) above it; the measured number falls inside the stated range.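

On the core of compound 3, isopropyl in place of methyl on an amide-type nitrogen gave a 2.6-fold lower number from compound 3 to compound 4 (0.42 log units; beyond the scatter) in this assay, whereas on the core of compound 1 the step stayed within the scatter. The two steps cannot be told apart, so the change carried over between these two cores as far as the numbers can show: the same change on two cores in this assay, a 1.5-fold lower number (0.16 log units; within the scatter) from compound 2 to compound 1 and a 2.6-fold lower number (0.42 log units; beyond the scatter) from compound 3 to compound 4, 1.8-fold (0.26 log units) apart, within the scatter of two such steps Two pairs do not show that a step of this size would hold on any further core.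

The compounds shown leave open what a longer chain, a tert-butyl group or a chain bearing an amine would give on the same amide-type nitrogen. They also leave open what a plain amide with no carbon group there would give.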